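This account rests on a few compounds, and the source may have more. Where it says the series, first, only, none or still open, it means among the compounds named here.

Compound 1 `CCc1ccc(N(CC(C)C)S(=O)(=O)c2ccc3c(c2)CCC(C2CCOCC2)O3)cc1`: 5.38
Compound 2 `CC(C)CN(c1ccccc1F)S(=O)(=O)c1ccc2c(c1)C(O)CC(C1CCOCC1)O2`: 3.39

In a physicochemical assay for lipophilicity, at pH 7.4 (on this read-out higher numbers stand for higher lipophilicity and lower numbers for lower lipophilicity), compound 1 stands highest of the two measured compounds at 5.38, and compound 2 gives 3.39, a gap beyond the scatter. Compound 3 `CCc1ccc(N(CC(C)C)S(=O)(=O)c2ccc3c(c2)C(OC)CC(C2CCOCC2)O3)cc1` has not yet been measured and keeps the core of compound 1 with one change: methoxy in place of hydrogen on a saturated ring carbon, two ring bonds from the ring atom that bears the oxan-4-yl group. Among the compounds with values here, no measured pair isolates this change, and compound 1 and compound 2 differ in more than one place. Within the data shown here, their gap therefore sets no size for the step. A modest downward step in this assay is expected, though one within the scatter cannot be excluded. The estimated change is a number 0.48 log units lower from compound 1 to compound 3 (beyond the scatter). For compound 3 the estimate is 4.9, with an expected range of 4.4 to 5.4.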

Compound 3, distribution coefficient: 4.69
The estimate for compound 3 lay 0.21 log units above the measured number; low and high end bracket the measured number.
By their numbers in this assay, from the lowest: compound 2; then compound 3; then compound 1.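

Methoxy in place of hydrogen on a saturated ring carbon, two ring bonds from the ring atom that bears the oxan-4-yl group, now has a measured size in this assay: the number moves a number 0.69 log units lower from compound 1 to compound 3 (beyond the scatter) and the step counts as modest. Within the data shown here, this is the first pair that differs in one place, so it shows that this ring carbon takes a methoxy group with a downward step beyond the scatter. Nothing at hand gives a cause for the step.

From the compounds shown here alone, one group at one position sets no trend, and it remains open how an amine, a carboxylic acid or a longer chain such as ethoxy on this ring carbon would compare. Compound 2 carries a hydroxy group on the same ring carbon but differs from compound 3 in more than one place, so that group has no readable step of its own.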